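The source may report more compounds than this note shows. Statements on the series, on what has been measured and on what is new or still open speak of the compounds shown alone.

Measured so far:
compound 1 `CCN(CC)C(=O)c1ccc(S(=O)(=O)N2CCC[C@@H](C(=O)N3CCC(F)(F)CC3)C2)cc1` — 70 nM
compound 2 `CCN(CC)S(=O)(=O)c1ccc(S(=O)(=O)N2CCC[C@@H](C(=O)NC3COC3)C2)cc1` — 2340 nM

Two compounds carry numbers in a functional assay on MIA PaCa-2 cells (Homo sapiens) for inhibition, read by MTT assay, with a stated time of 7 days; on this read-out higher numbers stand for weaker inhibition and lower numbers for stronger inhibition. Compound 1 gives 70 nM and compound 2 gives 2340 nM; compound 2 therefore stands highest of the two, with compound 1 well below it. The two differ in more than one place, so no single step can be read between them.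

Compound 3 `CCN(CC)S(=O)(=O)c1ccc(S(=O)(=O)N2CCC[C@@H](C(=O)N[C@H]3CC[C@@H](OC)CC3)C2)cc1` is not yet measured. It differs from compound 2 in one place: 4-methoxycyclohexyl in place of oxetan-3-yl on an amide-type nitrogen. Within the data shown here, no measured pair shows this change on its own, so its size cannot be taken from the data. A step toward a lower number in this assay is expected for compound 3, of a size that may or may not reach beyond the scatter; the expected step is a 2.9-fold lower number from compound 2 to compound 3 (0.47 log units; beyond the scatter). The estimate for compound 3 is 800 nM, with a range from 200 nM to 3000 nM.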

Compound 3, half-maximal inhibitory concentration: 960 nM
The estimate for compound 3 lay 1.2-fold (0.08 log units) below the measured number; measured number inside the range.
By their numbers in this assay, from the lowest: compound 1; then compound 3; then compound 2.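

In this assay the amide-type nitrogen gets its first single-place reading: 4-methoxycyclohexyl in place of oxetan-3-yl gives a 2.4-fold lower number from compound 2 to compound 3 (0.39 log units; beyond the scatter) as a modest move beyond the scatter. The position thus accepts a six-membered carbon ring with 2 defined stereocentres and 8 heavy atoms in place of a four-membered ring with 4, while the counted hydrogen-bond donors and acceptors of the group stay the same. Nothing measured on these compounds accounts for the step.

Steps to compound 1 cannot be read, as it differs from the others in more than one place. Open at this nitrogen are the plain cyclohexyl and 4-aminocyclohexyl groups, which would show what the methoxy contributes, and the other stereoisomers of 4-methoxycyclohexyl.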